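The source may report more compounds than this note shows. Statements on the series, on what has been measured and on what is new or still open speak of the compounds shown alone.

The series shares one core, and compound 1 `CC(C)NC(=O)N1CCN(C(=S)SCc2cn(Cc3ccccc3F)nn2)CC1` and compound 2 `CCN(C)C(=O)N1CCN(C(=S)SCc2cn(Cc3ccccc3F)nn2)CC1` differ only in the amine on the carbonyl carbon. In a functional assay on MCF7 cells (Homo sapiens) for cytotoxicity, read by MTT assay, with a stated time of 72 h (on this read-out higher numbers stand for weaker inhibition and lower numbers for stronger inhibition), compound 1 gives 1860 nM. In this assay, for the measured compounds named here, compound 2 gives 7210 nM, which places compound 2 at the higher of the two numbers measured so far, with compound 1 as its only neighbour; the step of a 3.9-fold higher number from compound 1 to compound 2 (0.59 log units; beyond the scatter) is the single comparison available.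

Compound 3 `O=C(NC1CCCCC1)N1CCN(C(=S)SCc2cn(Cc3ccccc3F)nn2)CC1` is the next variation at the same position: cyclohexylamino in place of ethyl(methyl)amino on a carbonyl carbon. Going by the values given here, the one measured step that bears on this change is a 3.9-fold higher number from compound 1 to compound 2 (0.59 log units; beyond the scatter), in which a secondary amine with one hydrogen-bond donor was replaced by a tertiary one with none and the number rose. Compound 3 reverses that feature, bringing back a hydrogen-bond donor while the ring-bearing substituent is larger than the isopropyl of compound 1. From that single step, the number for compound 3 is expected to fall from compound 2, by roughly a 4.0-fold lower number from compound 2 to compound 3 (0.60 log units; beyond the scatter), back toward the region of compound 1. For compound 3 in this assay the estimate is 1800 nM, with a range of 700 nM to 5000 nM.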

Compound 3, half-maximal inhibitory concentration: 85000 nM
For compound 3 the middle estimate is 47-fold (1.67 log units) below the measured one, outside the stated range (above it).
By their numbers in this assay, from the lowest: compound 1; then compound 2; then compound 3.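

Restoring the amide hydrogen did not by itself bring the number back down: in this assay, the step of a 12-fold higher number from compound 2 to compound 3 (1.07 log units; beyond the scatter) runs in the same direction as the earlier step of a 3.9-fold higher number from compound 1 to compound 2 (0.59 log units; beyond the scatter), so compound 2, which lacks that hydrogen, does not give the highest number of the three. The more direct comparison is a 46-fold higher number from compound 1 to compound 3 (1.66 log units; beyond the scatter), in which both compounds keep the amide hydrogen and cyclohexyl stands in place of isopropyl on an amide-type nitrogen, showing that this position responds strongly to the identity of that substituent even when the hydrogen is retained. The data offered here include no independent measurement that accounts for the large rise with cyclohexyl.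

These compounds do not separate the effect of having a ring from that of the substituent's overall size, a question that cyclopropylamino, cyclopentylamino or an open-chain hexylamino group would bear on. Going by these compounds, it also remains open whether a hydroxyl group or an amine on the cyclohexyl ring would change the number, and whether a ring closed onto the nitrogen, as in piperidine, would behave like the ethyl(methyl)amino group of compound 2.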